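From Nitro to Fluoro: Expected Loss of Paw Edema Inhibition

The source may hold more compounds than are shown below. What is called first, only, known or untested is meant among the compounds shown, and "the series" means these compounds.

Measured so far:
Compound 1, `Clc1ccccc1OCC1=NCCO1`, gives 22.2%.
Compound 2, `O=[N+]([O-])c1ccccc1OCC1=NCCO1`, gives 35.5%.

Both compounds were tested in a functional assay on the whole organism for inhibition, with Rattus norvegicus as the target, read by paw edema, with a stated time of 30 min, at a dose of 40 mg/kg by the oral route; a lower number here means a weaker effect, a higher number a stronger effect of the compound at the dose given. Going by the values given here, compound 2 stands highest of the two numbers; its only neighbour, compound 1, lies lower, and the step of a number 13.3 percentage points higher from compound 1 to compound 2 (beyond the scatter) is the single measured change, nitro taking the place of chloro. Compound 3, `Fc1ccccc1OCC1=NCCO1`, has not yet been measured. It differs from compound 2 in this way: fluoro in place of nitro on an aromatic carbon. Among the compounds with values here, the one measured step bears on it, since it shows that exchanging chloro for nitro raised the number by a modest amount beyond the scatter; the present change removes that nitro again and puts in fluoro, a halogen like chloro. A drop of roughly the same size is therefore expected, a number 13.5 percentage points lower from compound 2 to compound 3 (beyond the scatter). Compound 3 is estimated to give 22% in this assay, within a range from 8% to 36%.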

Compound 3, a percentage reported as inhibition, in the whole organism at one dose (the size of the read-out at that dose, not a potency): 30.5%
Compound 3: middle estimate off by 8.5 percentage points, on the low side; the measured number falls inside the stated range.
By their numbers in this assay, from the lowest: compounds 1, 3 and 2 (each within the scatter of the next, the first and the last beyond it).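

In this assay, fluoro in place of nitro on this aromatic carbon gives a number 5 percentage points lower from compound 2 to compound 3 (within the scatter) and fluoro in place of chloro gives a number 8.3 percentage points higher from compound 1 to compound 3 (within the scatter). Compound 3 therefore cannot be told apart from either of the others, even though compound 1 and compound 2 differ beyond the scatter, so the nitro group, with its 3 heavy atoms and 2 hydrogen-bond acceptors, is not needed for a reading in the range of compound 2. No measurement at hand explains how these three groups compare.

Going by these compounds, it remains open how an amine, a carboxylic acid or a longer chain such as an ethoxy group would read at this place. On these data alone, it is also open whether the three compounds would separate more clearly at other doses or times.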